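The compounds below may be only part of what the source reports. "The series", "measured", "known", "first", "only" and "open" are said of these compounds alone.

Compound 1 `Cc1cc2c(c3c1C[C@@H]1[C@@H](C)CO[C@]1(C)O3)C[C@@H]1[C@@H](C)CO[C@]1(C)O2` gives the highest number of the three measured compounds in a functional assay on aorta (Rattus norvegicus, strain Sprague-Dawley) for inhibition (a higher number here means that more compound is needed for the effect, a lower number that less compound is needed), at 52000 nM. Compound 2 `C#CCOc1cc2c(c3c1C[C@@H]1[C@@H](C)CO[C@]1(C)O3)C[C@@H]1[C@@H](C)CO[C@]1(C)O2` gives 22000 nM, and compound 3 `C=C=CCOc1cc2c(c3c1C[C@@H]1[C@@H](C)CO[C@]1(C)O3)C[C@@H]1[C@@H](C)CO[C@]1(C)O2` gives 11000 nM. The unmeasured compound 4 `CCCCOc1cc2c(c3c1C[C@@H]1[C@@H](C)CO[C@]1(C)O3)C[C@@H]1[C@@H](C)CO[C@]1(C)O2` differs from compound 1 in one place: butoxy in place of methyl on an aromatic carbon. Both measured steps away from compound 1 also replaced that methyl with an oxygen-linked chain, and both lowered the number: a 2.4-fold lower number from compound 1 to compound 2 (0.37 log units; beyond the scatter) and a 4.7-fold lower number from compound 1 to compound 3 (0.67 log units; beyond the scatter). Between those two chains the difference was small, a 2.0-fold lower number from compound 2 to compound 3 (0.30 log units; within the scatter). Since butoxy likewise enters through an oxygen on that aromatic carbon, a modest lowering is expected in this assay, roughly a 2.6-fold lower number from compound 1 to compound 4 (0.41 log units; beyond the scatter). Compound 4 is therefore estimated at 20000 nM, with a likely range from 8000 nM to 50000 nM.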

Compound 4, half-maximal effective concentration: > 200000 nM
Compound 4 was reported as a limit (the forecaster's own chance of this, stated with the estimate: 5%); middle value at least 10-fold (1.00 log units) away from the limit.
By their numbers in this assay, from the lowest: compounds 3 and 2 (each within the scatter of the next); then compound 1. At a limit, above all of these: compound 4.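

Compound 4 is reported only as a limit of the assay: the limit of > 200000 nM in this assay, at which 1 of the 4 values shown sits.

So an oxygen-linked chain on this aromatic carbon does not by itself lower the number, since butoxy gives an at least 3.8-fold higher number from compound 1 to compound 4 (0.58 log units; beyond the scatter), opposite to the direction seen with compounds 2 and 3. The end of the chain matters too: propyl in place of ethynyl gives an at least 9.0-fold higher number from compound 2 to compound 4 (0.95 log units; beyond the scatter), and propyl in place of propa-1,2-dien-1-yl gives an at least 18-fold higher number from compound 3 to compound 4 (1.25 log units; beyond the scatter).

Still open, on these data alone, is how methoxy or ethoxy would behave at this position, and whether a butoxy chain ending in an amine or a carboxylic acid would bring the number back down.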